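Trading chloro for bromo in a small halogen set

This account rests on a few compounds, and the source may have more. Where it says the series, first, only, none or still open, it means among the compounds named here.

In a functional assay on MCF7 cells (Homo sapiens) for cytotoxicity, read by MTT assay, with a stated time of 72 h (on this read-out lower numbers stand for stronger inhibition and higher numbers for weaker inhibition), compound 1 `Cn1ccc2c(Oc3ccc(NC(=O)c4cc5cccnc5n(-c5ccccc5)c4=O)cc3F)ncnc21`, which has hydrogen at the changing position, gives 73400 nM. Compound 2 `Cn1ccc2c(Oc3ccc(NC(=O)c4cc5cccnc5n(-c5ccc(F)cc5)c4=O)cc3F)ncnc21`, the fluoro version, gives 11900 nM, and compound 3 `Cn1ccc2c(Oc3ccc(NC(=O)c4cc5cccnc5n(-c5ccc(Cl)cc5)c4=O)cc3F)ncnc21`, the chloro version, gives 75000 nM. Compound 3 therefore stands level with compound 1, and both lie well away from compound 2. The measured steps show this pattern: a 6.2-fold lower number from compound 1 to compound 2 (0.79 log units; beyond the scatter) for fluoro in place of hydrogen, a 1.0-fold higher number from compound 1 to compound 3 (0.01 log units; within the scatter) for chloro in place of hydrogen, and a 6.3-fold higher number from compound 2 to compound 3 (0.80 log units; beyond the scatter) for chloro in place of fluoro.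

Compound 4 `Cn1ccc2c(Oc3ccc(NC(=O)c4cc5cccnc5n(-c5ccc(Br)cc5)c4=O)cc3F)ncnc21` makes one further change: bromo in place of chloro on an aromatic carbon. Among the compounds with values here, no measured step makes this swap, and three compounds cannot establish a halogen trend. The closest guide is a 1.0-fold higher number from compound 1 to compound 3 (0.01 log units; within the scatter), so no step beyond the scatter is expected in this assay. The estimated change is a 1.2-fold lower number from compound 3 to compound 4 (0.06 log units; within the scatter). Compound 4 is expected to give about 65000 nM, within an estimated range of 22000 nM to 150000 nM.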

Compound 4, half-maximal inhibitory concentration: 59400 nM
Estimate against measurement, compound 4: 1.1-fold (0.04 log units) above; the measured number falls inside the stated range.
By their numbers in this assay, from the lowest: compound 2; then compounds 4, 1 and 3 (each within the scatter of the next).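

In this assay, bromo on the 4-bromophenyl group cannot be told apart from chloro (a 1.3-fold lower number from compound 3 to compound 4 (0.10 log units; within the scatter)) or from hydrogen (a 1.2-fold lower number from compound 1 to compound 4 (0.09 log units; within the scatter)), while compound 2, the fluoro version, remains clearly separate (a 5.0-fold higher number from compound 2 to compound 4 (0.70 log units; beyond the scatter)). The halogen series therefore does not form a steady trend: of the three halogens tested at this position, only fluoro gives a step beyond the scatter from hydrogen, whereas chloro and bromo do not. Nothing in the data given explains why fluoro alone stands apart.

Going by these compounds, it remains open whether a group other than a halogen, such as methoxy, an amine or a carboxylic acid, would shift the number at this position. It is also unknown whether the gap between compound 2 and the other three compounds would recur in a different cell line.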